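Removing the Fluoro Group from a Thiourea Series

The source may report more compounds than this note shows. Statements on the series, on what has been measured and on what is new or still open speak of the compounds shown alone.

In a functional assay on HepG2 cells (Homo sapiens) for antiproliferative activity, read by MTT assay (a higher number here means a weaker inhibitor, a lower number a stronger inhibitor), compound 1 `CNC(=O)c1ccc(Oc2cccc(NC(=S)Nc3ccc(C)cc3)c2)nc1` gives 65400 nM. Compound 2 `CNC(=O)c1ccc(Oc2cccc(NC(=S)Nc3ccc(F)cc3)c2)nc1` gives 42500 nM in this assay, and the step of a 1.5-fold lower number from compound 1 to compound 2 (0.19 log units; within the scatter) stays within the scatter. Compound 3 `CNC(=O)c1ccc(Oc2cccc(NC(=S)Nc3ccc(F)c(C(F)(F)F)c3)c2)nc1` gives 20200 nM in this assay, and the step of a 2.1-fold lower number from compound 2 to compound 3 (0.32 log units; beyond the scatter) is a modest one beyond the scatter. Compound 3 therefore holds the lowest number of the three measured, with compound 2 nearest and compound 1 furthest away.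

Compound 4 `CNC(=O)c1ccc(Oc2cccc(NC(=S)Nc3cccc(C(F)(F)F)c3)c2)nc1` differs from compound 3 by hydrogen in place of fluoro on an aromatic carbon, on an aromatic carbon of a six-membered aromatic ring of carbon only, ortho to a trifluoromethyl group and para to a large group. The step of a 1.5-fold lower number from compound 1 to compound 2 (0.19 log units; within the scatter) bears on this change most directly, since it altered the same position and stayed within the scatter, while a 2.1-fold lower number from compound 2 to compound 3 (0.32 log units; beyond the scatter) shows the trifluoromethyl group, which compound 4 keeps, is what moved the number. The expected step of a 1.3-fold higher number from compound 3 to compound 4 (0.11 log units; within the scatter) is therefore small, with no clear direction beyond the scatter. For compound 4 the estimate in this assay is 26000 nM, within a range from 11000 nM to 60000 nM.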

Compound 4, half-maximal inhibitory concentration: 23300 nM
For compound 4 the middle estimate is 1.1-fold (0.05 log units) above the measured one, within the range that was stated.
By their numbers in this assay, from the lowest: compounds 3, 4, 2 and 1 (each within the scatter of the next, the first and the last beyond it).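

In this assay, the step of a 1.2-fold higher number from compound 3 to compound 4 (0.06 log units; within the scatter) shows that, ortho to a trifluoromethyl group, hydrogen and fluoro cannot be told apart, so compound 4 keeps the standing of compound 3 without the fluoro group. The 3-(trifluoromethyl)phenyl group alone also gives the step of a 2.8-fold lower number from compound 1 to compound 4 (0.45 log units; beyond the scatter) against 4-methylphenyl, which is modest but beyond the scatter. Against 4-fluorophenyl, however, the step of a 1.8-fold lower number from compound 2 to compound 4 (0.26 log units; within the scatter) stays within the scatter, so 3-(trifluoromethyl)phenyl is separated from only one of these two groups. No measurement at hand explains these results.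

The compounds shown leave open how an amine or a methoxy group at this place would read in this assay and whether hydrogen and fluoro would still match if the trifluoromethyl group were replaced by a nitrile.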